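Chain homologation of the primary amine in compound 1

The compounds below may be only part of what the source reports. "The series", "measured", "known", "first", "only" and "open" are said of these compounds alone.

Measured so far:
compound 1 `Cc1cc(-c2ccccc2)nnc1NCCCN` — 0.1 mg/kg
compound 2 `CCN(CC)CCNc1nnc(-c2ccccc2)cc1C` — > 10 mg/kg
compound 3 `CCCN(CCC)CCNc1nnc(-c2ccccc2)cc1C` — 2 mg/kg

In a functional assay on the whole organism with Mus musculus as the target (a lower number here means that less compound is needed, a higher number that more compound is needed for the effect), compound 1 gives 0.1 mg/kg, the lowest of the two numbers shown; the nearest is a 20-fold higher number from compound 1 to compound 3 (1.30 log units; beyond the scatter). For compound 2 the assay gives only a limit, (the limit of > 10 mg/kg in this assay, at which 1 of the 3 values shown sits). Compound 4 `Cc1cc(-c2ccccc2)nnc1NCCCCN` differs from compound 1 by aminomethyl in place of amino on a saturated chain carbon, three bonds along the chain from a nitrogen on an aromatic ring. Within the data shown here, no measured step varies this chain length: the steps of an at least 100-fold higher number from compound 1 to compound 2 (2.00 log units; beyond the scatter) and a 20-fold higher number from compound 1 to compound 3 (1.30 log units; beyond the scatter) both alter the amine substitution instead, and an at least 5.0-fold lower number from compound 2 to compound 3 (0.69 log units; beyond the scatter) compares two dialkylated amines. So compound 4 keeps the primary amine that separates compound 1 from compound 2 and compound 3, and a step of a 2.0-fold higher number from compound 1 to compound 4 (0.30 log units; within the scatter) near the scatter is expected. Compound 4 is estimated at 0.2 mg/kg, between 0.05 mg/kg and 1 mg/kg.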

Compound 4, minimum effective dose: 0.1 mg/kg
Compound 4: the middle estimate sits 2.0-fold (0.30 log units) above what was measured; low and high end bracket the measured number.
By their numbers in this assay, from the lowest: compounds 1 and 4 (each within the scatter of the next); then compound 3. At a limit, above all of these: compound 2.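

In this assay, 4-aminobutyl in place of 3-aminopropyl is tolerated at this position (no change at the digits printed from compound 1 to compound 4 (within the scatter)), so the extended chain keeps the read-out of the primary amine. The large gap to the dialkylated amines also holds for the longer primary amine (a 20-fold lower number from compound 3 to compound 4 (1.30 log units; beyond the scatter)) and (an at least 100-fold lower number from compound 2 to compound 4 (2.00 log units; beyond the scatter)). Compound 2 stands only at a limit: the limit of > 10 mg/kg in this assay, at which 1 of the 4 values shown sits.

Compounds 2 and 3 carry their amines on a shorter chain, so chain length and amine substitution remain confounded; a primary 2-aminoethyl group would separate them. From the compounds shown here alone, whether 5-aminopentyl or a methylamino chain end is tolerated remains open.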